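This account rests on a few compounds, and the source may have more. Where it says the series, first, only, none or still open, it means among the compounds named here.

Working notes on the series. Compound 1 `C=C1C(=O)OC[C@H]1CCOC(=O)Nc1ccc(C(C)C)cc1` is the reference point. In an ADME assay on RAW264.7 cells (Mus musculus) for cytotoxicity, read by MTT assay, with a stated time of 18 h (on this read-out lower numbers stand for higher toxicity in this test and higher numbers for lower toxicity in this test), compound 1 gives 12400 nM. Compound 2 `C=C1C(=O)OC[C@H]1CCOC(=O)Nc1ccc(F)cc1F`, with a different substitution on the aromatic ring, gives 24500 nM in this assay; the two numbers lie within the usual scatter of each other, so compound 1 and compound 2 do not separate on this read-out, and compound 1 stands at one end of a pair that spans no more than the scatter.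

Compound 3 `C=C1C(=O)OC[C@H]1CCOC(=O)Nc1ccc(CC)cc1` is not yet measured. It differs from compound 1 in one place: hydrogen in place of methyl on a saturated chain carbon bound to an aromatic carbon and a saturated chain carbon. Among the compounds with values here, no measured pair covers this kind of change, so nothing here fixes its size; the loss of a single carbon at this position is expected to give a step of no more than the scatter, in either direction.

The estimate for compound 3 in this assay is 12000 nM, with a range from 6000 nM to 25000 nM, corresponding to an expected step of a 1.0-fold lower number from compound 1 to compound 3 (0.01 log units; within the scatter).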

Compound 3, half-maximal cytotoxic concentration: 11400 nM
The estimate for compound 3 lay 1.1-fold (0.02 log units) above the measured number; the range from low to high includes it.
By their numbers in this assay, from the lowest: compounds 3, 1 and 2 (each within the scatter of the next, the first and the last beyond it).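

The pair compound 1 and compound 3 gives the series its first one-place comparison: in this assay, the change from isopropyl to ethyl, hydrogen in place of methyl on a saturated chain carbon bound to an aromatic carbon and a saturated chain carbon, gives a 1.1-fold lower number from compound 1 to compound 3 (0.04 log units; within the scatter). On this read-out, isopropyl and ethyl do not separate at this place, so the loss of this one carbon has no size that can be told from the scatter. No measured evidence on the cause of this result is at hand.

This single pair does not show whether a longer chain, such as butyl, or a tert-butyl group would give a step beyond the scatter from compound 1. On these data alone, whether an amine or a carboxylic acid at this place would do so also remains open.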